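Volume of distribution notes: carbonyl substituent on the pyrrolidine urea/amide

The source may hold more compounds than are shown below. What is called first, only, known or untested is meant among the compounds shown, and "the series" means these compounds.

Measured so far in an ADME assay (Rattus norvegicus, strain Wistar Han) for pharmacokinetics; on this read-out higher numbers stand for wider distribution into tissues and lower numbers for narrower distribution:
compound 1 `CCn1c(-c2ccc(C(F)(F)F)nc2)nc2c(O[C@H]3CCN(C(=O)N4CC(OC)C4)C3)ncnc21`: 0.2 L/kg
compound 2 `CCn1c(-c2cnc(C)nc2)nc2c(O[C@H]3CCN(C(=O)C4CCC4)C3)ncnc21`: 0.6 L/kg
compound 3 `CCn1c(-c2ccc(C(F)(F)F)nc2)nc2c(O[C@H]3CCN(C(=O)C4CC4)C3)ncnc21`: 0.7 L/kg

Compound 2 sits within the scatter of compound 3, and its number lies beyond the scatter above that of compound 1. Going by the values given here, the one step measured in this assay that changes the group on the carbonyl carbon is a 3.5-fold higher number from compound 1 to compound 3 (0.54 log units; beyond the scatter), a modest rise when an acceptor-bearing ring leaves and a plain carbocycle enters.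

Compound 4 `CCn1c(-c2cnc(C)nc2)nc2c(O[C@H]3CCN(C(=O)C4CCOC4)C3)ncnc21` has not yet been measured. It differs from compound 2 as follows: oxolan-3-yl in place of cyclobutyl on a carbonyl carbon. Among the compounds with values here, this is the reverse sense of the one measured step: a carbocycle leaves and a ring carrying one hydrogen-bond acceptor enters. Within the data shown here, on that basis a decrease in this assay from compound 2 to compound 4 is expected, of similar or somewhat smaller size than the step from compound 1 to compound 3, since only one such step exists and the two changes are not the same groups. Compound 4 is therefore estimated at 0.4 L/kg, with a range of 0.2 L/kg to 0.8 L/kg. The expected step is a 1.5-fold lower number from compound 2 to compound 4 (0.18 log units; within the scatter).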

Compound 4, volume of distribution: 0.5 L/kg
Beside the measured number, compound 4's estimate is 1.3-fold (0.10 log units) below it; measured number inside the range.
By their numbers in this assay, from the lowest: compound 1; then compounds 4, 2 and 3 (each within the scatter of the next).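

In this assay, going by these compounds alone, the first swap of a plain carbocycle for a ring carrying a hydrogen-bond acceptor with the amide-type nitrogen kept as the carbonyl's neighbour gives a 1.2-fold lower number from compound 2 to compound 4 (0.08 log units; within the scatter), so oxolan-3-yl and cyclobutyl cannot be told apart at this position. Within the data shown here, a ring acceptor on the carbonyl carbon is therefore not enough by itself to give a number as low as that of compound 1 at 0.2 L/kg, and the earlier step, a 3.5-fold higher number from compound 1 to compound 3 (0.54 log units; beyond the scatter), can no longer be read as a general contrast between acceptor-bearing rings and carbocycles, since only that step lies beyond the scatter and it involves different groups on a different shared part. Nothing available explains why 3-methoxyazetidin-1-yl and oxolan-3-yl behave differently in these two pairs.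

Going by these compounds, whether 3-methoxyazetidin-1-yl would give a similarly low number on the shared part of compound 2 remains open, and this would separate the effect of that group from the effect of its surroundings. Also open, on these data alone, is how a piperidin-4-yl ring amine or a carboxylic acid on the carbonyl carbon would move the number relative to cyclobutyl.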